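The source may hold more compounds than are shown below. What is called first, only, known or untested is meant among the compounds shown, and "the series" means these compounds.

Measured compounds: compound 1, `CCCCCc1ccc(-c2cc3cn([C@H]4C[C@H](OC(=O)[C@@H](NC(=O)[C@@H]5CCCN5C(=O)[C@@H](N)C(C)C)C(C)C)[C@@H](COC(=O)[C@@H](NC(=O)[C@@H]5CCCN5C(=O)[C@@H](N)C(C)C)C(C)C)O4)c(=O)nc3o2)cc1`, giving 77000 ug/mL in a physicochemical assay for solubility, with a stated time of 24 h; on this read-out lower numbers stand for lower solubility and higher numbers for higher solubility; compound 2, `CCCCCc1ccc(-c2cc3cn([C@H]4C[C@H](O)[C@@H](COC(=O)[C@@H](NC(=O)[C@@H]5CCCN5C(=O)[C@@H](N)CC(N)=O)C(C)C)O4)c(=O)nc3o2)cc1`, giving 39000 ug/mL.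

Compound 2 and compound 1 give numbers within the usual scatter of each other, so compound 2 cannot be set apart from compound 1 on this assay. Compound 3, `CCCCCc1ccc(-c2cc3cn([C@H]4C[C@H](O)[C@@H](COC(=O)[C@@H](NC(=O)[C@@H]5CCCN5C(=O)[C@@H](N)CC(=O)O)C(C)C)O4)c(=O)nc3o2)cc1`, differs from compound 2 by hydroxy in place of amino on a carbonyl carbon. Within the data shown here, no measured pair carries this change, so the step from compound 2 to compound 3 in this assay is expected to be none beyond the scatter. Compound 3 is therefore estimated at 45000 ug/mL, within 15000 ug/mL to 120000 ug/mL, which means a step of a 1.2-fold higher number from compound 2 to compound 3 (0.06 log units; within the scatter).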

Compound 3, solubility: 15000 ug/mL
The estimate for compound 3 lay 3.0-fold (0.48 log units) above the measured number; measured number inside the range.
By their numbers in this assay, from the lowest: compound 3; then compounds 2 and 1 (each within the scatter of the next).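

Swapping amino for hydroxy on this carbonyl carbon, which turns carbamoyl into carboxy, gives a 2.6-fold lower number from compound 2 to compound 3 (0.41 log units; beyond the scatter) in this assay. This is the first change in one place among the compounds shown, and it shows that the read-out responds to this swap at this position by more than the usual scatter. Nothing at hand bears on why the number drops. As far as these compounds go, whether a methyl ester or an amine at this place would read closer to compound 2 or compound 3 remains open. So does whether a longer chain ending in carboxy would show the same step.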